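The source may report more compounds than this note shows. Statements on the series, on what has been measured and on what is new or still open speak of the compounds shown alone.

Measured compounds:
- compound 1, `Cc1ccc(Cc2nc(N)c3nn(-c4ccccc4)cc3n2)cc1`: 39%
- compound 2, `Nc1nc(Cc2cccc(C(F)(F)F)c2)nc2cn(-c3ccccc3)nc12`: 41%

Both compounds share the same core and differ only in the group hanging from the saturated chain carbon bound to an aromatic carbon. In an assay on CHO cells for displacement of a labelled ligand from adenosine receptor A3 (Homo sapiens), read by scintillation counting, tested at 1 uM (on this read-out lower numbers stand for less inhibition and higher numbers for more inhibition at the one concentration tested (going by the name of the read-out)), compound 1 gives 39%, and compound 2 gives 41%. Compound 1 has the lower of the two numbers, but the two values lie within the usual scatter of each other, so nothing separates them. Compound 1 is the starting point of the step considered here.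

Compound 3, `Nc1nc(CCCc2ccccc2)nc2cn(-c3ccccc3)nc12`, is not yet measured. It keeps the core of compound 1 and changes only the group on the chain: phenethyl in place of 4-methylphenyl on a saturated chain carbon bound to an aromatic carbon. The two measured compounds show that swapping one substituted six-membered ring for another in this place leaves the number where it was. Lengthening the chain by one carbon is a different kind of change, for which no measured pair is available; the expectation for this assay is therefore a step no larger than the scatter, with a slight lean downward as the phenyl ring is moved further from the core, giving an expected step of a number 5 percentage points lower from compound 1 to compound 3 (within the scatter). Compound 3 is estimated at 34%, with a range from 14% to 56%.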

Compound 3, a percentage reported as inhibition, at one concentration (the size of the read-out at that concentration, not a potency): 12%
Compound 3: middle estimate off by 22 percentage points, on the high side; measured number below the stated range.
By their numbers in this assay, from the lowest: compound 3; then compounds 1 and 2 (each within the scatter of the next).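

In this assay, phenethyl in place of 4-methylphenyl on a saturated chain carbon bound to an aromatic carbon gives a number 27 percentage points lower from compound 1 to compound 3 (beyond the scatter) and so shows that this place is not indifferent to the group it carries, something compound 1 and compound 2 could not show with their values within the scatter of each other. The change looks small on paper: both groups hold one six-membered aromatic ring of carbon only, neither has a hydrogen-bond donor, a hydrogen-bond acceptor or a net charge, and the group grows only from 7 to 8 heavy atoms, yet that is enough for a step beyond the scatter. No measurement here explains why the number falls with this change.

The change alters two things at once, the link to the ring and the methyl on the ring, so the compounds shown leave open which of the two matters, and a benzyl group with no methyl on its ring would help to separate them. Also open, as far as these compounds go, is whether a longer chain, such as phenylpropyl, or an amine at the end of the chain would take the number further down or bring it back.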